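Cytotoxicity of 2-benzylthio-oxadiazole phenols: O-benzylation of compound 1

The source may report more compounds than this note shows. Statements on the series, on what has been measured and on what is new or still open speak of the compounds shown alone.

Measured so far:
compound 1 `COc1cc(-c2nnc(SCc3ccc([N+](=O)[O-])cc3)o2)ccc1O` — 688000 nM
compound 2 `COc1cc(-c2nnc(SCc3ccc(C)cc3)o2)ccc1O` — 549000 nM

Both numbers come from an ADME assay on cells (Mus musculus, strain BALB/c) for cytotoxicity, read by MTT assay, with a stated time of 24 h; a higher number here means that more compound is tolerated, a lower number that less compound is tolerated. Compound 1 gives the highest of the two numbers, and its nearest neighbour is compound 2, the gap a 1.3-fold lower number from compound 1 to compound 2 (0.10 log units; within the scatter). Among the measured compounds shown here, that step exchanges one group on the benzyl ring, far from the phenol, and it stays inside the scatter; no compound in the set has yet been altered at the phenolic oxygen.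

Compound 3 `COc1cc(-c2nnc(SCc3ccc([N+](=O)[O-])cc3)o2)ccc1OCc1ccc([N+](=O)[O-])cc1` is the next compound to go into this assay. Relative to compound 1 the change is 4-nitrobenzyl in place of hydrogen on an oxygen on an aromatic ring.

For the measured compounds named here, no measured step bears on this change directly. Going by the values given here, the one step available, from compound 1 to compound 2, is within the scatter, and it does not touch the oxygen altered here. With nothing in the series pointing either way, the expectation is no step beyond the scatter, with the range left open toward a lower number given the size of the entering group: the expected step is a 1.5-fold lower number from compound 1 to compound 3 (0.18 log units; within the scatter). For compound 3 the estimate is 450000 nM, with a range from 150000 nM to 1000000 nM.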

Compound 3, half-maximal cytotoxic concentration: 156000 nM
Estimate against measurement, compound 3: 2.9-fold (0.46 log units) above; measured number inside the range.
By their numbers in this assay, from the lowest: compound 3; then compounds 2 and 1 (each within the scatter of the next).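

In this assay, among the compounds shown here, 4-nitrobenzyl in place of hydrogen on the oxygen on the aromatic ring gives a 4.4-fold lower number from compound 1 to compound 3 (0.64 log units; beyond the scatter) and is the first step to lie beyond the scatter. The only earlier step, a 1.3-fold lower number from compound 1 to compound 2 (0.10 log units; within the scatter), exchanges a group on the benzyl ring and stays within the scatter, so among the compounds shown this oxygen is the only place where a single change has moved the number beyond the scatter. Nothing measured on these compounds accounts for the step.

Hydroxy gives way to (4-nitrobenzyl)oxy in one change. The series cannot yet separate the loss of the hydroxy hydrogen from the entry of the whole group, and a methyl ether or a plain benzyl ether on the same oxygen would be needed to tell these apart. Also open, going by these compounds, is whether the nitro group of the entering benzyl contributes at all, which an amine or a carboxylic acid at that point on the entering ring, or a longer chain between the oxygen and the ring, could begin to test.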